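A few compounds are considered here, and "the series" means these few. Any claim that something is new, unique, unknown or untested is made for them only; others in the source may bear on it.

Compound 2 `COc1ccc(/C=C/c2cc(OC)cc(OC)c2/C=C/C(=O)c2ccccc2C)cc1` was tested in a functional assay on B16-F10 cells (Mus musculus) for antiproliferative activity, read by MTT assay, with a stated time of 48 h (on this read-out higher numbers stand for weaker inhibition and lower numbers for stronger inhibition), and gave 6.1 ug/mL. Among the three compounds measured so far, this is the second highest number. Its nearest neighbour is compound 1 `COc1ccc(/C=C/c2cc(OC)cc(OC)c2/C=C/C(=O)c2ccc(C(F)(F)F)cc2)cc1`, which in this assay gave 4.3 ug/mL, the change being a 1.4-fold higher number from compound 1 to compound 2 (0.15 log units; within the scatter). The furthest is compound 3 `CCCCCCCCCCCCOc1ccc(C(=O)/C=C/c2c(/C=C/c3ccc(OC)cc3)cc(OC)cc2OC)cc1`, whose number in this assay of 12.7 ug/mL lies beyond the scatter from that of compound 2.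

Compound 4 `CCN(CC)c1ccc(C(=O)/C=C/c2c(/C=C/c3ccc(OC)cc3)cc(OC)cc2OC)cc1` has not yet been measured. It differs from compound 2 in one place: 4-(diethylamino)phenyl in place of 2-methylphenyl on a carbonyl carbon. Going by the values given here, the only measured step that alters this same place, the group on a carbonyl carbon, is the one from compound 1 to compound 2, and it stayed within the scatter. Compound 3 carries yet another group at that place, and its number is higher than that of compound 2, so the few examples at hand show no firm direction. Against that background, the step of a 1.1-fold higher number from compound 2 to compound 4 (0.06 log units; within the scatter) is expected to stay small. Compound 4 is therefore estimated to give 7 ug/mL in this assay, within a range from 3 ug/mL to 16 ug/mL.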

Compound 4, half-maximal inhibitory concentration: 8.1 ug/mL
For compound 4 the middle estimate is 1.2-fold (0.06 log units) below the measured one; low and high end bracket the measured number.
By their numbers in this assay, from the lowest: compounds 1, 2, 4 and 3 (each within the scatter of the next, the first and the last beyond it).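

Placing 4-(diethylamino)phenyl, with 11 heavy atoms and a hydrogen-bond acceptor, on the carbonyl carbon in place of 2-methylphenyl, with 7 heavy atoms and none, gives a 1.3-fold higher number from compound 2 to compound 4 (0.12 log units; within the scatter) in this assay, so this position accepts the larger nitrogen-bearing group without a clear loss of inhibition. Diethylamino in place of trifluoromethyl on an aromatic carbon gives a 1.9-fold higher number from compound 1 to compound 4 (0.28 log units; within the scatter), so even this exchange does not separate the two compounds, and compounds 1, 2 and 4 form a group in which each step shown stays within the usual scatter. Nothing available explains why these changes leave the number so little altered.

On these data alone, whether a carboxylic acid or a primary amine on that aromatic carbon would move the number beyond the scatter remains open. Also open, as far as these compounds go, is whether a smaller amine, such as dimethylamino, or a morpholine ring would behave like diethylamino there.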